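From 4-methylphenyl to 3-chlorophenyl: estimating growth inhibition

The source may hold more compounds than are shown below. What is called first, only, known or untested is meant among the compounds shown, and "the series" means these compounds.

- compound 1 `CC1=CC[C@@H]([C@@](C)(O)CCCC(C)(C)NC(=S)N/N=C\c2ccc(C)cc2)CC1`: 11600 nM
- compound 2 `CC1=CC[C@@H]([C@@](C)(O)CCCC(C)(C)NC(=S)N/N=C\c2ccccc2[N+](=O)[O-])CC1`: 6050 nM
- compound 3 `CC1=CC[C@@H]([C@@](C)(O)CCCC(C)(C)NC(=S)N/N=C\c2ccccc2Cl)CC1`: 53300 nM

In a functional assay on UACC-62 cells (Homo sapiens) for cytotoxicity, read by sulforhodamine B assay (a lower number here means a stronger inhibitor of growth, a higher number a weaker inhibitor of growth), compound 1 gives 11600 nM, which lies within the scatter of compound 2 and under compound 3. Compound 4 `CC1=CC[C@@H]([C@@](C)(O)CCCC(C)(C)NC(=S)N/N=C\c2cccc(Cl)c2)CC1` has not been measured yet. It differs from compound 1 in one place: 3-chlorophenyl in place of 4-methylphenyl on a carbon with a double bond to nitrogen. Two measured swaps at that same place bear on it. The closer guide brings in 2-chlorophenyl, giving a 4.6-fold higher number from compound 1 to compound 3 (0.66 log units; beyond the scatter). The other brings in 2-nitrophenyl, giving a 1.9-fold lower number from compound 1 to compound 2 (0.28 log units; within the scatter). Neither shows what 3-chlorophenyl does, so a small rise is expected, possibly none beyond the scatter. The expected step is a 1.7-fold higher number from compound 1 to compound 4 (0.24 log units; within the scatter). For compound 4 the estimated value is 20000 nM, with an expected range from 7000 nM to 55000 nM.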

Compound 4, concentration for 50% growth inhibition: 7810 nM
The estimate for compound 4 lay 2.6-fold (0.41 log units) above the measured number; the range from low to high includes it.
By their numbers in this assay, from the lowest: compounds 2, 4 and 1 (each within the scatter of the next); then compound 3.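

In this assay the place of the chlorine matters, with a 6.8-fold lower number from compound 3 to compound 4 (0.83 log units; beyond the scatter), so 3-chlorophenyl and 2-chlorophenyl are not interchangeable here. Yet 3-chlorophenyl does not separate from the other two groups, with a 1.5-fold lower number from compound 1 to compound 4 (0.17 log units; within the scatter) and a 1.3-fold higher number from compound 2 to compound 4 (0.11 log units; within the scatter); both steps lie within the scatter, leaving compound 3 as the only one apart from the rest. No measurement shown accounts for this difference between the two chlorophenyl groups. Still open, from the compounds shown here alone, is whether an amine or a carboxylic acid in place of the chlorine would track compound 4 or compound 3.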